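The source may hold more compounds than are shown below. What is called first, only, known or untested is meant among the compounds shown, and "the series" means these compounds.

Compound 1 `Cc1nn(C)c2c1C(c1ccccc1)=NCC(=O)N2` is the parent of this small series; in a functional assay on the whole organism (strain Holtzman) with Rattus norvegicus as the target (a higher number here means that more compound is needed for the effect, a lower number that less compound is needed), compound 1 gives 10 mg/kg. Adding a chloro on the phenyl ring gives compound 2 `Cc1nn(C)c2c1C(c1ccccc1Cl)=NCC(=O)N2`, which in this assay gives 2.5 mg/kg, and exchanging the methyl on the core for chloro gives compound 3 `Cn1nc(Cl)c2c1NC(=O)CN=C2c1ccccc1`, which gives 40 mg/kg. Compound 2 therefore stands with the lowest number of the three measured, with a 4.0-fold lower number from compound 1 to compound 2 (0.60 log units; beyond the scatter) taking it away from compound 1, while a 4.0-fold higher number from compound 1 to compound 3 (0.60 log units; beyond the scatter) moves in the opposite direction, so that compound 3 lies furthest from compound 2.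

Compound 4 `CCCCc1nn(C)c2c1C(c1ccccc1Cl)=NCC(=O)N2` is not yet measured. It differs from compound 2 by propyl in place of hydrogen on a saturated chain carbon bound to an aromatic carbon. Neither measured step touches this kind of change: a 4.0-fold lower number from compound 1 to compound 2 (0.60 log units; beyond the scatter) concerns a chloro on the phenyl ring, and a 4.0-fold higher number from compound 1 to compound 3 (0.60 log units; beyond the scatter) concerns a chloro replacing the methyl on the core rather than any lengthening of that methyl. The measured steps show only that this position on the core is sensitive to substitution. Without a comparable step, the expectation is for no change beyond the scatter, with a wide range in either direction; the estimated step is a 1.6-fold higher number from compound 2 to compound 4 (0.20 log units; within the scatter). Compound 4 is thus expected to give about 4 mg/kg, within a range from 1.5 mg/kg to 12 mg/kg.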

Compound 4, minimum effective dose: > 40 mg/kg
Compound 4: only a limit was reported; the forecaster's own chance of this, stated with the estimate: 5%; middle value at least 10-fold (1.00 log units) away from the limit.
By their numbers in this assay, from the lowest: compound 2; then compound 1; then compound 3.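

In this assay compound 4 gives > 40 mg/kg, which is a limit of the assay and not a number: the limit of > 40 mg/kg in this assay, at which 1 of the 4 values shown sits.

Read as methyl to butyl on the core, the change gives an at least 16-fold higher number from compound 2 to compound 4 (1.20 log units; beyond the scatter), a large step that lies beyond the scatter. The earlier compounds had shown that this position responds when chloro replaces the methyl, but they said nothing about the carbon chain itself. Compound 4 adds that lengthening the chain alone, with only carbon entering and the chloro on the phenyl ring kept in place, is enough to produce a large step in the direction of needing more compound.

The compounds shown leave open how short a chain must be to avoid this loss, as neither ethyl nor propyl at this position is among them, and the limit leaves the full size of the step unknown. They also leave open whether the outcome depends on chain length alone or would differ for a chain ending in an amine or a carboxylic acid, or for a cyclopropyl group in place of the butyl.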